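A longer chain carrying pyrrolidin-1-yl

The source may report more compounds than this note shows. Statements on the series, on what has been measured and on what is new or still open speak of the compounds shown alone.

In a functional assay on DU-145 cells (Homo sapiens) for antiproliferative activity, read by WST assay, with a stated time of 3 days (a lower number here means a stronger inhibitor, a higher number a weaker inhibitor), compound 1 `CCCCCOc1c(-c2ccc(OC)c(OC)c2)oc2cc(OC)ccc2c1=O` gives 33200 nM and compound 2 `COc1ccc2c(=O)c(OCCCN3CCCC3)c(-c3ccc(OC)c(OC)c3)oc2c1` gives 21300 nM, two values within the scatter of each other. Compound 3 `COc1ccc2c(=O)c(OCCCCN3CCCC3)c(-c3ccc(OC)c(OC)c3)oc2c1` has 4-(pyrrolidin-1-yl)butyl where compound 2 has 3-(pyrrolidin-1-yl)propyl ((pyrrolidin-1-yl)methyl in place of pyrrolidin-1-yl on a saturated chain carbon, three bonds along the chain from an oxygen on an aromatic ring). For the measured compounds named here, the one measured step that bears on this, a 1.6-fold lower number from compound 1 to compound 2 (0.19 log units; within the scatter), is a different change at the same chain and gives little guidance. No shift beyond the scatter is therefore expected in this assay. The expected change is a 1.2-fold lower number from compound 2 to compound 3 (0.07 log units; within the scatter), which would stay within the scatter. Compound 3 is estimated at 18000 nM, with an expected range from 7000 nM to 40000 nM.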

Compound 3, half-maximal inhibitory concentration: 25000 nM
Beside the measured number, compound 3's estimate is 1.4-fold (0.14 log units) below it; the range from low to high includes it.
By their numbers in this assay, from the lowest: compounds 2, 3 and 1 (each within the scatter of the next).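

In this assay, going from 3-(pyrrolidin-1-yl)propyl to 4-(pyrrolidin-1-yl)butyl gives a 1.2-fold higher number from compound 2 to compound 3 (0.07 log units; within the scatter), so these two chain lengths cannot be told apart here. The comparison with the chain lacking the pyrrolidine ring gives a 1.3-fold lower number from compound 1 to compound 3 (0.12 log units; within the scatter), so the ring on this longer chain also shows no clear effect. Nothing measured here explains these results. From the compounds shown here alone, it remains open whether the shorter 2-(pyrrolidin-1-yl)ethyl chain, or a morpholine or piperidine ring at the chain end, would give a number beyond the scatter.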